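A few compounds are considered here, and "the series" means these few. Any claim that something is new, unique, unknown or untested is made for them only; others in the source may bear on it.

Of the compounds shown here, three share one core and have been measured in an assay on cells for antagonist activity at Toll-like receptor 4 (Homo sapiens), with a stated time of 24 h; on this read-out lower numbers stand for stronger inhibition and higher numbers for weaker inhibition. Compound 1 `Cc1ccc(OCCC(O)CN(C)Cc2c(C)nn(Cc3ccccc3Cl)c2C)cc1` gives 51500 nM in this assay. Compound 2 `CCc1ccc(OCCC(O)CN(C)Cc2c(C)nn(Cc3ccccc3Cl)c2C)cc1`, which carries a 2.0-fold lower number from compound 1 to compound 2 (0.30 log units; within the scatter), gives 26000 nM. Compound 3 `CCOc1ccc(OCCC(O)CN(C)Cc2c(C)nn(Cc3ccccc3C)c2C)cc1` gives 54600 nM, the highest of the three numbers; its gap to compound 1 is within the scatter, while its gap to compound 2 lies beyond it. Compound 4 `CCOc1ccc(OCCC(O)CN(C)Cc2c(C)nn(Cc3ccc(Cl)cc3)c2C)cc1` has not yet been measured. It differs from compound 3 in one place: 4-chlorophenyl in place of 2-methylphenyl on a saturated chain carbon bound to an aromatic nitrogen. For the measured compounds named here, no measured step touches this position. Going by the values given here, the only measured step, from compound 1 to compound 2, changes the group on the other aromatic ring and stays within the scatter, and compounds 1 and 3 differ in two places at once, so their values show no single-change comparison. On this basis the step from compound 3 to compound 4 in this assay is expected to be a 1.1-fold lower number from compound 3 to compound 4 (0.04 log units; within the scatter), nothing beyond the scatter. Compound 4 is therefore estimated at 50000 nM in this assay, between 15000 nM and 160000 nM.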

Compound 4, half-maximal inhibitory concentration: 25900 nM
For compound 4 the middle estimate is 1.9-fold (0.29 log units) above the measured one; the measured number falls inside the stated range.
By their numbers in this assay, from the lowest: compounds 4, 2, 1 and 3 (each within the scatter of the next, the first and the last beyond it).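

In this assay the change from 2-methylbenzyl to 4-chlorobenzyl gives a 2.1-fold lower number from compound 3 to compound 4 (0.32 log units; beyond the scatter) and is the first step shown at this place, on a saturated chain carbon bound to an aromatic nitrogen. For the compounds shown here, it shows that the read-out responds to the group held here, whereas the only earlier step, a 2.0-fold lower number from compound 1 to compound 2 (0.30 log units; within the scatter), changed the other aromatic ring and stayed within the scatter. No measurement offered here accounts for the new step.

The change replaces methyl with chlorine and also moves the substituent on the ring, and the compounds shown do not separate these two parts of the step. From the compounds shown here alone, it also remains open how an unsubstituted benzyl group or a benzyl ring carrying a carboxylic acid would read at this place.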